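Para substituent swap on the cyanoaziridine urea series

This account rests on a few compounds, and the source may have more. Where it says the series, first, only, none or still open, it means among the compounds named here.

Of the compounds shown here, two carry numbers so far. Compound 1 `CCOC(=O)c1ccc(NC(=O)N2CC2C#N)cc1` is the weaker of the pair: in a functional assay on MCF7 cells (Homo sapiens) for inhibition (a lower number here means a stronger inhibitor, a higher number a weaker inhibitor), compound 1 gives 3300 nM. Compound 2 `N#CC1CN1C(=O)Nc1ccc(C(F)(F)F)cc1` stands at the lower end of the two values, and in this assay compound 2 gives 1300 nM. Among the compounds with values here, the only step so far, a 2.5-fold lower number from compound 1 to compound 2 (0.40 log units; beyond the scatter), came from exchanging the group on the aromatic carbon, so substitution at that position is known to shift the read-out by a modest amount.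

Compound 3 `N#CC1CN1C(=O)Nc1ccc(S(N)(=O)=O)cc1` continues at the same position: sulfamoyl in place of trifluoromethyl on an aromatic carbon. Within the data shown here, no measured step involves sulfamoyl, so the single step from compound 1 to compound 2 is the only guide, and it tells how much one exchange at that carbon can move the number, not in which direction this one will go. The expectation for compound 3 is therefore a shift no larger than that earlier step, with the direction uncertain, so a 1.9-fold higher number from compound 2 to compound 3 (0.28 log units; within the scatter) is taken as the estimated change. Compound 3 is estimated at 2500 nM in this assay, within a range of 800 nM to 8000 nM.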

Compound 3, half-maximal inhibitory concentration: > 15000 nM
Compound 3 ended at the assay's limit; the forecaster's own chance of this, stated with the estimate: 5%; middle value at least 6.0-fold (0.77 log units) from the limit.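

In this assay compound 3 rests at a limit of the assay and not at a number: the limit of > 15000 nM in this assay, at which 1 of the 3 values shown sits. Sulfamoyl in place of trifluoromethyl gives an at least 11-fold higher number from compound 2 to compound 3 (1.06 log units; beyond the scatter), and sulfamoyl in place of ethoxycarbonyl gives an at least 4.5-fold higher number from compound 1 to compound 3 (0.65 log units; beyond the scatter), so the two earlier compounds both keep a measurable number while this exchange does not. Within the data shown here, the only earlier step, a 2.5-fold lower number from compound 1 to compound 2 (0.40 log units; beyond the scatter), suggested a modest range for this aromatic carbon, whereas the new steps show that a single exchange there can take the read-out to the end of the assay's range, and the true size of that loss stays unknown at a limit.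

Sulfamoyl differs from trifluoromethyl in its atoms and in carrying a hydrogen-bond donor and hydrogen-bond acceptors, and the three compounds do not separate these features, so which of them matters remains open. A methylsulfonyl group at the same carbon would keep the sulfur and both oxygens without the nitrogen, while an amine or a carboxylic acid there would show whether the loss extends beyond sulfamoyl.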